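Aryl ether to chloro on the shared core

The compounds below may be only part of what the source reports. "The series", "measured", "known", "first", "only" and "open" are said of these compounds alone.

Measured compounds in a functional assay on PANC-1 cells (Homo sapiens) for inhibition, read by MTT assay, with a stated time of 48 h; a higher number here means a weaker inhibitor, a lower number a stronger inhibitor:
Compound 1 `Cc1nnsc1CO/N=C/c1c(C)nn(C)c1Oc1ccccc1Cl` gives > 50000 nM, a limit.
Compound 2 `Cc1nnsc1CO/N=C/c1c(C)nn(C)c1Oc1ccc(F)cc1` gives > 50000 nM, a limit.
Compound 3 `Cc1ccc(Oc2c(/C=N/OCc3snnc3C)c(C)nn2C)cc1` gives > 50000 nM, a limit.

Compound 3 stands where the other two stand: all three values are limits of this assay (the limit of > 50000 nM in this assay, at which 3 of the 3 values shown sit), so none of the three can be placed above or below another. The steps among them are unreadable for the same reason: a step that the two limits leave unreadable from compound 1 to compound 2, a step that the two limits leave unreadable from compound 1 to compound 3 and a step that the two limits leave unreadable from compound 2 to compound 3 each run from one limit to another, and whether the aryl group on the oxygen matters cannot be told from these numbers.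

Compound 4 `Cc1nnsc1CO/N=C/c1c(C)nn(C)c1Cl` is not yet measured. Its change from compound 3 is chloro in place of 4-methylphenoxy on an aromatic carbon. For the measured compounds named here, none of the measured steps touches this change; the three all vary the group on the oxygen, and in compound 4 the oxygen itself leaves together with the whole 4-methylphenoxy group. Going by the values given here, the only guide is the level of the series so far, where compound 3 sits at the limit > 50000 nM. On that guide compound 4 is expected to sit at or near the limit as well, a step that the limit leaves unreadable from compound 3 to compound 4 that is no more than a guess. For compound 4 the estimate in this assay is 60000 nM, between 15000 nM and 250000 nM, with a real chance that only a limit is reported again.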

Compound 4, half-maximal inhibitory concentration: 26600 nM
Estimate against measurement, compound 4: 2.3-fold (0.35 log units) above; measured number inside the range.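

Chloro in place of the aryloxy group on this aromatic carbon of the five-membered ring is the only change shown that gives a number rather than a limit: in this assay compound 4 gives 26600 nM, so a measurable value in the series does not depend on an aryl ether at this position. The change reads as an at least 1.8-fold lower number from compound 3 to compound 4 (0.27 log units; that floor lies within the scatter), and the other two aryl ethers give the same reading, an at least 1.8-fold lower number from compound 2 to compound 4 (0.27 log units; that floor lies within the scatter) and an at least 1.8-fold lower number from compound 1 to compound 4 (0.27 log units; that floor lies within the scatter), so the data do not establish a drop beyond the scatter for any of the three. These steps are floors and not full sizes because compounds 1, 2 and 3 each stand at a limit of the assay: the limit of > 50000 nM in this assay, at which 3 of the 4 values shown sit.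

Going by these compounds, the steps among compounds 1, 2 and 3 remain unreadable, and how far past the limit those three lie is open, so the true size of the change from aryloxy to chloro is unknown. Also open, on these data alone, is how an amine, a methoxy group or a plain hydrogen on this carbon would stand against the chloro of compound 4.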